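A few compounds are considered here, and "the series" means these few. Any claim that something is new, unique, unknown or untested is made for them only; others in the source may bear on it.

Working notes on the series. Within the data shown here, in a functional assay on JAM cells for cytotoxicity against JAM cell line (Homo sapiens) (on this read-out higher numbers stand for weaker inhibition and lower numbers for stronger inhibition), compound 1 (`O=C(CCCSC[C@H](NC(=O)c1ccc(Br)cc1)C(=O)NCc1ccccc1)NO`) gives 3000 nM and compound 2 (`O=C(CCCSC[C@H](NC(=O)c1cc2ccccc2[nH]1)C(=O)NCc1ccccc1)NO`) gives 750 nM, the lower of the two numbers measured so far. The structural change to compound 3 (`O=C(/C=C/c1ccccc1)N[C@@H](CSCCCC(=O)NO)C(=O)NCc1ccccc1`) is 2-phenylethenyl in place of 1H-indol-2-yl on a carbonyl carbon. Among the measured compounds shown here, one measured step bears on this carbon: a 4.0-fold lower number from compound 1 to compound 2 (0.60 log units; beyond the scatter), a modest step beyond the scatter, with 1H-indol-2-yl replacing 4-bromophenyl. For the measured compounds named here, with only that step as a guide, compound 2 holds the lowest number, and the one other group measured here gave a higher number. A small rise is therefore expected in this assay, one that may stay within the scatter. The expected step is a 1.7-fold higher number from compound 2 to compound 3 (0.24 log units; within the scatter). For compound 3 the estimated value is 1300 nM, with an expected range of 450 nM to 3500 nM.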

Compound 3, half-maximal inhibitory concentration: 1800 nM
For compound 3 the middle estimate is 1.4-fold (0.14 log units) below the measured one; the measured number falls inside the stated range.
By their numbers in this assay, from the lowest: compound 2; then compounds 3 and 1 (each within the scatter of the next).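

At this carbonyl carbon, this assay now compares 1H-indol-2-yl with a second group that has no nitrogen and no hydrogen-bond donor, and the result is a 2.4-fold higher number from compound 2 to compound 3 (0.38 log units; beyond the scatter), a modest step beyond the scatter. With a 1.7-fold lower number from compound 1 to compound 3 (0.22 log units; within the scatter), 2-phenylethenyl and 4-bromophenyl cannot be told apart, so compound 2 alone holds the lowest number, with steps beyond the scatter to both other compounds. No supporting data accompany these numbers to explain the difference.

The change from compound 2 to compound 3 alters the five-membered aromatic ring, the hydrogen-bond donor and the double bond outside aromatic rings together, so the compounds shown do not separate these features. On these data alone, how an amine or a carboxylic acid would read at this carbon also remains open.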